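The source may report more compounds than this note shows. Statements on the series, on what has been measured and on what is new or still open speak of the compounds shown alone.

Measured so far in a functional assay on A-375 cells (Homo sapiens) for inhibition, read by MTT assay, with a stated time of 120 h; on this read-out lower numbers stand for stronger inhibition and higher numbers for weaker inhibition:
compound 1 `CC(NC(=O)/C=C/Oc1ccc(NC(=O)Nc2cc(C(F)(F)F)ccc2Cl)cc1)c1ccccc1`: 16000 nM
compound 2 `C/C(=C\c1ccc(NC(=O)Nc2ccc(Cl)c(C(F)(F)F)c2)cc1)C(=O)NC(C)c1ccccc1`: > 50000 nM, a limit of the assay and not a number

Going by the values given here, compound 1 holds the only numerical value in this assay. The value for compound 2 is a limit; (the limit of > 50000 nM in this assay, at which 1 of the 2 values shown sits). Among the compounds with values here, no step between the two measured compounds is set down, as compound 1 and compound 2 differ in more than one place; their two values show only that compound 1 gives a number where compound 2 gives a limit.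

Compound 3 `CC(NC(=O)/C=C/Oc1ccc(NC(=O)Nc2ccc(Cl)c(C(F)(F)F)c2)cc1)c1ccccc1` has yet to be measured in this assay. It differs from compound 1 in one place, the two having the same atoms, joined differently: 4-chloro-3-(trifluoromethyl)phenyl in place of 2-chloro-5-(trifluoromethyl)phenyl on an amide-type nitrogen. Within the data shown here, the entering group is the one also carried by compound 2, which however differs from compound 3 elsewhere, so nothing measured bears directly on this change. The step from compound 1 to compound 3 is expected to be a 1.3-fold lower number from compound 1 to compound 3 (0.12 log units; within the scatter), within the scatter and without a clear direction. Compound 3 is therefore estimated at 12000 nM, in the range 3000 nM to 50000 nM.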

Compound 3, half-maximal inhibitory concentration: 20700 nM
Compound 3: the middle estimate sits 1.7-fold (0.24 log units) below what was measured; low and high end bracket the measured number.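

In this assay, 4-chloro-3-(trifluoromethyl)phenyl in place of 2-chloro-5-(trifluoromethyl)phenyl on an amide-type nitrogen gives a 1.3-fold higher number from compound 1 to compound 3 (0.11 log units; within the scatter), so the two arrangements of the same atoms cannot be told apart on this read-out. The 4-chloro-3-(trifluoromethyl)phenyl group now also stands in a compound with a numerical value, compound 3 at 20700 nM. Compound 2, which carries the same group, stands at a limit of the assay and not a number, and it differs from compound 3 in more than one place, so no step to it can be read: the limit of > 50000 nM in this assay, at which 1 of the 3 values shown sits.

As far as these compounds go, only these two arrangements of chlorine and trifluoromethyl are covered on the phenyl ring at this place, so it stays open whether a plain phenyl, or a nitrile in place of the trifluoromethyl, would move the number beyond the scatter. From the compounds shown here alone, what an amine or a carboxylic acid elsewhere on the shared core would do to the read-out also stays open.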